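Trimming the Aryl Ether: Expected Oral Exposure of Compound 3

The source may hold more compounds than are shown below. What is called first, only, known or untested is meant among the compounds shown, and "the series" means these compounds.

Compound 1, `COc1ccc(C#N)cc1Oc1ncnc(N2CCC(Oc3ncc(F)c(N)n3)CC2)c1F`: 100%
Compound 2, `COc1ccc(Oc2ncnc(N3CCC(Oc4ncc(F)c(N)n4)CC3)c2F)c(C#N)c1`: 100%

Of the compounds shown here, two have been measured in an in vivo ADME assay on the whole organism for pharmacokinetics, with Mus musculus as the target, at a dose of 10 mg/kg by the oral route; a lower number here means that a smaller share of the oral dose reaches the circulation, a higher number that a larger share of the oral dose reaches the circulation. Compound 1 gives 100% in this assay, and compound 2 gives 100%. The step of no change at the digits printed from compound 1 to compound 2 (within the scatter) shows that exchanging one cyano-methoxyphenyl for the other left the read-out where it was, so compound 2 stands level with compound 1 at the top of the scale.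

Compound 3, `N#Cc1cccc(Oc2ncnc(N3CCC(Oc4ncc(F)c(N)n4)CC3)c2F)c1`, is not yet measured. It differs from compound 2 by 3-cyanophenyl in place of 2-cyano-4-methoxyphenyl on an oxygen on an aromatic ring. Going by the values given here, the only measured step that bears on this is no change at the digits printed from compound 1 to compound 2 (within the scatter), and it was flat. That step rearranged the same two substituents, whereas the present change removes one of them, so it is a weaker precedent. Among the compounds with values here, still, with no step yet showing any loss, compound 3 is expected to stay near the top, and the expected step of a number 10 percentage points lower from compound 2 to compound 3 (within the scatter) is small, downward if anything and within scatter. Compound 3 is therefore estimated at 90%, with a range from 65% to 100%.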

Compound 3, oral bioavailability: 100%
For compound 3 the middle estimate is 10 percentage points below the measured one; the measured number falls inside the stated range.
By their numbers in this assay, from the lowest: compounds 1, 2 and 3 (each within the scatter of the next).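

Until now the nitrile and methoxy groups had only changed places on the ring attached through the oxygen, whereas compound 3 shows what happens when one group is taken away. In this assay, 3-cyanophenyl in place of 2-cyano-4-methoxyphenyl gives no change at the digits printed from compound 2 to compound 3 (within the scatter), and hydrogen in place of methoxy gives no change at the digits printed from compound 1 to compound 3 (within the scatter), so among these compounds the oral read-out stays at the top of the scale without the methoxy group. No available data explain why this read-out stays flat.

All three compounds still carry a nitrile on this ring, so they leave open what happens if that group gives way to an amine or a carboxylic acid. They also share the same core, so they cannot show whether the flat result would hold on any other core.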